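Swapping chloro for bromo on the aryl group

A few compounds are considered here, and "the series" means these few. Any claim that something is new, unique, unknown or untested is made for them only; others in the source may bear on it.

Measured compounds:
- compound 1 `Brc1cn2ccnc2c(-c2ccc3ncn(C4CCCCC4)c3c2)n1`: 26.3%
- compound 2 `Clc1ccc(-c2cn3ccnc3c(-c3ccc4ncn(C5CCCCC5)c4c3)n2)cc1`: 8.87%

Both compounds were tested in a functional assay on MOLT-4 cells (Homo sapiens) for inhibition, read by sulforhodamine B assay, with a stated time of 48 h, tested at 10 uM; a higher number here means more inhibition at the concentration tested (going by the name of the read-out), a lower number less inhibition. Compound 1 gives 26.3% and compound 2 gives 8.87%, so compound 2 stands lowest of the two numbers, its nearest neighbour being compound 1 at a number 17.4 percentage points lower from compound 1 to compound 2 (beyond the scatter).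

Compound 3 `Brc1ccc(-c2cn3ccnc3c(-c3ccc4ncn(C5CCCCC5)c4c3)n2)cc1` has not yet been measured. It differs from compound 2 in one place: bromo in place of chloro on an aromatic carbon.

For the measured compounds named here, the only measured step, a number 17.4 percentage points lower from compound 1 to compound 2 (beyond the scatter), concerns a different change, bromo giving way to 4-chlorophenyl, and it does not show how one halogen on the phenyl ring compares with another. Going by the values given here, no measured pair speaks directly to the change from chloro to bromo, so the step of a number 3.1 percentage points higher from compound 2 to compound 3 (within the scatter) is expected to stay within the scatter. Compound 3 is therefore estimated at 12%, with a range from 0% to 30%.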

Compound 3, a percentage reported as inhibition, at one concentration (the size of the read-out at that concentration, not a potency): 20.4%
Estimate against measurement, compound 3: 8.4 percentage points below; low and high end bracket the measured number.
By their numbers in this assay, from the lowest: compound 2; then compounds 3 and 1 (each within the scatter of the next).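

In this assay, a single atom at this place on the phenyl ring is enough to move the number: a number 11.5 percentage points higher from compound 2 to compound 3 (beyond the scatter). The new compound also changes the reading of the earlier step, since a number 5.9 percentage points lower from compound 1 to compound 3 (within the scatter), whereas a number 17.4 percentage points lower from compound 1 to compound 2 (beyond the scatter), so attaching a phenyl ring in place of bromo on the shared core does not by itself give a step beyond the scatter; the outcome depends on the halogen the ring carries. Nothing available explains why bromo and chloro differ at this place.

The compounds shown leave open how fluoro, methoxy or an amine would read at the same place on the phenyl ring. They also leave open whether the difference between chloro and bromo would hold at other concentrations, since a single concentration gives no potency.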